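The source may hold more compounds than are shown below. What is called first, only, known or untested is meant among the compounds shown, and "the series" means these compounds.

In a functional assay on HCT-116 cells (Homo sapiens) for cytotoxicity, read by sulforhodamine B assay, with a stated time of 48 h (a higher number here means a weaker inhibitor, a lower number a stronger inhibitor), compound 1 `CC(=O)n1nc(NC(=O)c2ccccc2)c2c1CN(C(=O)c1ccccc1)C2` gives 580 nM, compound 2 `CC(=O)n1nc(NC(=O)c2ccccc2)c2c1CN(C(=O)C1CCC(C)CC1)C2` gives 12200 nM, and compound 3 `CC(=O)n1nc(NC(=O)c2ccccc2)c2c1CN(C(=O)c1cccc(F)c1)C2` gives 21900 nM. Compound 3 therefore stands level with compound 2, as a 1.8-fold higher number from compound 2 to compound 3 (0.25 log units; within the scatter) shows, and well apart from compound 1. The large step of a 38-fold higher number from compound 1 to compound 3 (1.58 log units; beyond the scatter) came with fluoro in place of hydrogen on an aromatic carbon. The step of a 21-fold higher number from compound 1 to compound 2 (1.32 log units; beyond the scatter) was also large, but it involved 4-methylcyclohexyl in place of phenyl on a carbonyl carbon.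

Compound 4 `CC(=O)n1nc(NC(=O)c2ccccc2)c2c1CN(C(=O)c1cccc(Cl)c1)C2` carries chloro in place of fluoro on an aromatic carbon, meta to a large group (chloro in place of fluoro on an aromatic carbon). Among the measured compounds shown here, no measured step exchanges one of these halogens for the other, so only the fluoro step bears on this place, and it compares fluoro with hydrogen. Compound 3, at 21900 nM, remains the nearest anchor, so no change beyond the scatter is expected in this assay, though with wide uncertainty. The expected step is a 1.5-fold lower number from compound 3 to compound 4 (0.16 log units; within the scatter). Compound 4 is estimated at 15000 nM, within an expected range of 2500 nM to 50000 nM.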

Compound 4, half-maximal inhibitory concentration: 17400 nM
Compound 4: the middle estimate sits 1.2-fold (0.06 log units) below what was measured, and the stated range covers the measured number.
By their numbers in this assay, from the lowest: compound 1; then compounds 2, 4 and 3 (each within the scatter of the next).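

In this assay, exchanging 3-fluorophenyl for 3-chlorophenyl gives a 1.3-fold lower number from compound 3 to compound 4 (0.10 log units; within the scatter), so at this place on the aromatic ring the two halogens cannot be told apart, and the step of a 1.4-fold higher number from compound 2 to compound 4 (0.15 log units; within the scatter) likewise leaves the 3-chlorophenyl compound level with the 4-methylcyclohexyl compound. The large step away from the unsubstituted phenyl now appears with a second halogen, as a 30-fold higher number from compound 1 to compound 4 (1.48 log units; beyond the scatter) shows, so it is not particular to fluoro among the compounds shown. No available measurement explains why either halogen comes with this step. Going by these compounds, it remains open whether other groups at this place, such as methoxy, an amine or a nitrile, would stand as far from compound 1 as the halogens do. On these data alone, whether chloro placed elsewhere on the ring would do the same also remains open.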